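The source may hold more compounds than are shown below. What is called first, only, known or untested is meant among the compounds shown, and "the series" means these compounds.

For the measured compounds named here, compound 1 `O=C[C@@H]1CCC(=O)NCCn2cc(nn2)C[C@H](NC(=O)OCc2ccccc2)C(=O)N[C@@H](CC2CCCCC2)C(=O)N1` and compound 2 `CC(C)C[C@@H]1NC(=O)[C@@H](NC(=O)OCc2ccccc2)Cc2cn(nn2)CCCNC(=O)CC[C@@H](C=O)NC1=O` are two macrocycles on a shared core, and they are the only measured members here. In an ADME assay on HG23 cells (Homo sapiens) for cytotoxicity, with a stated time of 72 h (a higher number here means that more compound is tolerated, a lower number that less compound is tolerated), compound 1 gives > 100000 nM, which is a limit of the assay and not a number. In this assay compound 2 gives > 100000 nM, again a limit of the assay rather than a number. Both measured values therefore rest at the limit of > 100000 nM in this assay, at which 2 of the 2 values shown sit, so compound 2 stands at the very top of what the assay can report, tied with compound 1 and not distinguished from it.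

Compound 3 `O=C[C@@H]1CCC(=O)NCCCn2cc(nn2)C[C@H](NC(=O)OCc2ccccc2)C(=O)N[C@@H](CC2CCCCC2)C(=O)N1` has not yet been measured in this assay. It differs from compound 2 by cyclohexyl in place of isopropyl on a saturated chain carbon bound to a saturated ring carbon. Going by the values given here, no step between measured compounds exists here, so no measured shift can be consulted. Compound 1 already carries the cyclohexylmethyl group, and it sits at the same limit as compound 2.

For compound 3 a step from compound 2 of a step that the limit leaves unreadable from compound 2 to compound 3 is expected, that is, nothing beyond the scatter. Compound 3 is therefore estimated at 150000 nM, within 70000 nM to 300000 nM, and the assay is expected most likely to report only a limit once more.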

Compound 3, half-maximal cytotoxic concentration: > 100000 nM
Compound 3: no number, only a limit; the forecaster's own chance of this, stated with the estimate: 85%; the middle value is on the limit's open side.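

In this assay compound 3 gives > 100000 nM, a limit of the assay and not a number, so no step from compound 2 to compound 3 can be read: the limit of > 100000 nM in this assay, at which 3 of the 3 values shown sit.

The compounds shown leave open whether cyclohexyl in place of isopropyl changes tolerance at all, and at what concentration, if any, these macrocycles become cytotoxic.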